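Series notes: benzyl in place of enamine on the ring amine

The source may report more compounds than this note shows. Statements on the series, on what has been measured and on what is new or still open speak of the compounds shown alone.

Two compounds are measured: compound 1 `Cn1c(-c2ccc(NC(=O)CCl)cc2)nc(-c2ccccc2)c1-c1ccccc1` and compound 2 `CN(C)/C=C/N1CCN(CC(=O)Nc2ccc(-c3nc(-c4ccccc4)c(-c4ccccc4)n3C)cc2)CC1`. In a functional assay on MCF7 cells (Homo sapiens) for cytotoxicity, read by MTT assay, with a stated time of 24 h, tested at 80 ug/mL (on this read-out lower numbers stand for a weaker effect and higher numbers for a stronger effect at the one concentration tested), compound 1 gives 70%. In this assay compound 2 gives 34.7%, the lowest of the two numbers. Among the compounds with values here, the single measured step is a number 35.3 percentage points lower from compound 1 to compound 2 (beyond the scatter), a change at a different place. Compound 3 `Cc1ccc(CN2CCN(CC(=O)Nc3ccc(-c4nc(-c5ccccc5)c(-c5ccccc5)n4C)cc3)CC2)cc1` differs from compound 2 by 4-methylbenzyl in place of 2-(dimethylamino)ethenyl on an amine nitrogen in a ring. Within the data shown here, no measured step touches this position, so the data give no direction for the change. The expected step is a number 1.3 percentage points higher from compound 2 to compound 3 (within the scatter), not beyond the scatter. Compound 3 is therefore estimated at 36%, within 20% to 55%.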

Compound 3, a percentage reported as activity, at one concentration (the size of the read-out at that concentration, not a potency): 49.3%
The estimate for compound 3 lay 13.3 percentage points below the measured number, within the range that was stated.
By their numbers in this assay, from the lowest: compound 2; then compound 3; then compound 1.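

In this assay, 4-methylbenzyl in place of 2-(dimethylamino)ethenyl on the amine nitrogen in a ring gives a number 14.6 percentage points higher from compound 2 to compound 3 (beyond the scatter). The substituent on this nitrogen therefore affects the read-out, and here the all-carbon aromatic group is the higher-reading of the two. No measurement available here bears on the reason for this step.

The compounds shown leave open whether the step follows the aromatic ring or the methyl on it. Unsubstituted benzyl and a plain ethyl chain on the same nitrogen would separate these two features.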